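This account rests on a few compounds, and the source may have more. Where it says the series, first, only, none or still open, it means among the compounds named here.

Of the compounds shown here, three have been measured in an assay on IMR-32 cells for displacement of a labelled ligand from corticotropin-releasing factor receptor 1 (Homo sapiens), read by scintillation counting, with a stated time of 2 h; on this read-out lower numbers stand for stronger inhibition and higher numbers for weaker inhibition. Compound 1 `CCC(CC)Nc1nc(OC)c(-c2ccc(Cl)cc2Cl)nc1OC` gives 8.4 nM in this assay. Compound 2 `CCc1nc(NC(CC)CC)c(I)nc1-c1ccc(Cl)cc1Cl` gives 12 nM, and compound 3 `CCc1nc(NC(CC)CC)c(Cl)nc1-c1ccc(Cl)cc1Cl` gives 71 nM. Among the measured compounds shown here, compound 3 therefore stands highest of the three and is the weakest binder among them; its nearest neighbour is compound 2, and the single one-place step recorded so far, a 5.9-fold higher number from compound 2 to compound 3 (0.77 log units; beyond the scatter), separates the two.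

Compound 4 `CCc1nc(NC(CC)CC)c(OC)nc1-c1ccc(Cl)cc1Cl` has not yet been measured. It differs from compound 3 in one place: methoxy in place of chloro on an aromatic carbon. For the measured compounds named here, no measured pair swaps chloro for methoxy at this carbon, so the step from iodo to chloro is the only direct guide, and it shows that the group on this position can move the number well beyond the scatter. Compound 1, which also carries methoxy on the carbon ortho to a (pentan-3-yl)amino group but whose core differs elsewhere, gives 8.4 nM in this assay and offers a further hint that methoxy is tolerated here.

The expected step is a 4.7-fold lower number from compound 3 to compound 4 (0.68 log units; beyond the scatter). Compound 4 is therefore estimated at 15 nM, with a range from 5 nM to 50 nM.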

Compound 4, inhibition constant: 5.9 nM
Compound 4: the middle estimate sits 2.5-fold (0.41 log units) above what was measured; the measured number falls inside the stated range.
By their numbers in this assay, from the lowest: compounds 4, 1 and 2 (each within the scatter of the next, the first and the last beyond it); then compound 3.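

In this assay, among the compounds shown here, the group on this aromatic carbon, ortho to a (pentan-3-yl)amino group, matters more than the earlier compounds could show: methoxy in place of chloro gives a 12-fold lower number from compound 3 to compound 4 (1.08 log units; beyond the scatter) and counts as a large step. Methoxy also separates from iodo, with a 2.0-fold lower number from compound 2 to compound 4 (0.31 log units; beyond the scatter) beyond the scatter, so the three groups on this carbon now stand in a clear order, with methoxy giving the lowest number, iodo the next and chloro the highest. The other comparison concerns the carbon that carries the ethyl group, para to this position, and there ethyl and methoxy cannot be told apart, since a 1.4-fold lower number from compound 1 to compound 4 (0.15 log units; within the scatter) stays within the scatter.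

Going by these compounds, three groups on one carbon cannot show how far this trend reaches, so it remains open whether an ethoxy group, a hydroxy group or an amine here would give a number close to that of compound 4, or whether a longer chain in place of the ethyl group would keep the number in the same range. No measurement on hand explains why the methoxy and chloro compounds differ so widely.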